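This account rests on a few compounds, and the source may have more. Where it says the series, first, only, none or still open, it means among the compounds named here.

Measured so far in a functional assay on HUVEC cells (Homo sapiens) for inhibition, read by MTT assay, with a stated time of 24 h, tested at 10 uM; a lower number here means less inhibition of growth, a higher number more inhibition of growth at the concentration tested:

compound 1, `COc1cc2ccc(=O)oc2cc1OCCCCBr`: 11.2%
compound 2, `COc1cc2ccc(=O)oc2cc1OCC(O)CNC(C)C`: 0.1%

Compound 2 stands lowest of the two numbers in this assay; its nearest neighbour is compound 1, and the step of a number 11.1 percentage points lower from compound 1 to compound 2 (beyond the scatter) lies beyond the scatter but is modest in size.

Compound 3, `COc1cc2ccc(=O)oc2cc1OCC1CO1`, is not yet measured. It differs from compound 2 in one place: oxiran-2-yl in place of 1-hydroxy-2-(isopropylamino)ethyl on a saturated chain carbon bound to an oxygen on an aromatic ring. The group that enters is smaller than the one that leaves and carries no hydrogen-bond donor.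

For the measured compounds named here, only one measured step bears on this change, and only indirectly: the step from compound 1 to compound 2 replaced one chain on the same oxygen with another and gave a number 11.1 percentage points lower from compound 1 to compound 2 (beyond the scatter). Compound 3 carries neither of those two chains, so the step tells the direction that a chain swap at this position can take but not what the oxiran-2-yl group will do. Going by the values given here, with a single step of modest size as the only guide, the expected step of a number 7.9 percentage points higher from compound 2 to compound 3 (within the scatter) is a small rise, staying near the range spanned by the two measured compounds. Compound 3 is therefore estimated at 8% in this assay, with a range of -5% to 25%.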

Compound 3, percent growth inhibition at one concentration: 62.2%
Compound 3: middle estimate off by 54.2 percentage points, on the low side; the measured number lies above the stated range.
By their numbers in this assay, from the lowest: compound 2; then compound 1; then compound 3.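

In this assay, the group on the saturated chain carbon bound to an oxygen on an aromatic ring turns out to govern growth inhibition far more strongly than the earlier pair suggested: oxiran-2-yl gives a number 62.1 percentage points higher from compound 2 to compound 3 (beyond the scatter), and, set against 3-bromopropyl, it gives a number 51 percentage points higher from compound 1 to compound 3 (beyond the scatter). For the compounds shown here, both steps are large, whereas the only earlier step at this position was modest, and they place compound 3 clearly highest of the three on the shared core. The entering group is the only one of the three with a three-membered ring, and it has fewer heavy atoms than 1-hydroxy-2-(isopropylamino)ethyl and no hydrogen-bond donors, but no available measurement explains the rise.

The compounds shown leave open whether the rise belongs to the oxiran-2-yl ring itself or merely to the loss of the two longer chains. A cyclopropyl group, an open-chain diol or a short primary amine at the same place would help separate these readings, and a longer chain ending in oxiran-2-yl would show how far the ring tolerates being moved away from the core.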